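Replacing 4-nitrophenyl in compound 3

The source may hold more compounds than are shown below. What is called first, only, known or untested is meant among the compounds shown, and "the series" means these compounds.

Measured in a functional assay on HepG2 cells (Homo sapiens) for inhibition, read by MTT assay, with a stated time of 48 h; on this read-out lower numbers stand for stronger inhibition and higher numbers for weaker inhibition:
- compound 1 `Cc1c(NC(=O)NCCN2C(=O)S/C(=C\c3ccc([N+](=O)[O-])cc3)C2=O)c(=O)n(-c2ccccc2)n1C` gives 14000 nM
- compound 2 `COc1cc(/C=C2\SC(=O)N(CCNC(=O)Nc3c(C)n(C)n(-c4ccccc4)c3=O)C2=O)cc(OC)c1OC` gives 10800 nM
- compound 3 `Cc1c(NC(=O)CN2C(=O)S/C(=C\c3ccc([N+](=O)[O-])cc3)C2=O)c(=O)n(-c2ccccc2)n1C` gives 84300 nM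

Compound 3 has the highest number of the three, so it is the weakest inhibitor here, and its gaps to compound 1 and compound 2 both lie beyond the scatter. Compound 4 `Cc1cc(C)c(/C=C2\SC(=O)N(CC(=O)Nc3c(C)n(C)n(-c4ccccc4)c3=O)C2=O)c(C)c1` has 2,4,6-trimethylphenyl in place of 4-nitrophenyl on a double-bonded chain carbon bound to a double-bonded ring carbon. Going by the values given here, only one measured step swaps a group at this place, and it shows a 1.3-fold lower number from compound 1 to compound 2 (0.11 log units; within the scatter). Among the compounds with values here, that is thin evidence, since compound 1 and compound 2 carry a different chain from compound 3, and no measured compound holds 2,4,6-trimethylphenyl. Resting on that single step, no change beyond the scatter is expected in this assay, so the expected result is a 1.4-fold lower number from compound 3 to compound 4 (0.15 log units; within the scatter). The estimate for compound 4 is 60000 nM, with an expected range from 20000 nM to 140000 nM.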

Compound 4, half-maximal inhibitory concentration: 63500 nM
Beside the measured number, compound 4's estimate is 1.1-fold (0.02 log units) below it; the measured number falls inside the stated range.
By their numbers in this assay, from the lowest: compounds 2 and 1 (each within the scatter of the next); then compounds 4 and 3 (each within the scatter of the next).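

On the chain of compound 3, putting 2,4,6-trimethylphenyl in place of 4-nitrophenyl gives a 1.3-fold lower number from compound 3 to compound 4 (0.12 log units; within the scatter) in this assay and so extends the picture to a second chain. Going by these compounds alone, the only earlier swap at this place was made on the chain of compound 1. The new group also differs more in its atoms than a simple exchange of one ring for a similar one: it holds carbon only and has 0 hydrogen-bond acceptors where 4-nitrophenyl has 2, yet the number stays within the scatter. Nothing available here explains why the number holds steady.

Still open, going by these compounds, is whether an amine or a carboxylic acid on the phenyl ring at this place would move the number beyond the scatter. On these data alone, it is also open whether 2,4,6-trimethylphenyl would behave the same way on the chain of compound 1.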